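Chloro in place of fluoro: one step to read

A few compounds are considered here, and "the series" means these few. Any claim that something is new, unique, unknown or untested is made for them only; others in the source may bear on it.

Compound 1 `O=C(/C=C/c1cccc(S(=O)(=O)c2ccc3ccccc3n2)c1)NO` gives 270 nM in a functional assay on A549 cells (Homo sapiens) for antiproliferative activity, read by sulforhodamine B assay, with a stated time of 48 h (a lower number here means a stronger inhibitor of growth, a higher number a weaker inhibitor of growth), and serves as the reference point. Compound 2 `O=C(/C=C/c1cccc(S(=O)(=O)c2ccc3cccc(F)c3n2)c1)NO` gives 640 nM in this assay and holds the higher of the two numbers, which makes it the weaker inhibitor of growth of the pair. The measured step of a 2.4-fold higher number from compound 1 to compound 2 (0.37 log units; beyond the scatter) is modest and beyond the scatter, and it comes with fluoro in place of hydrogen on an aromatic carbon.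

Compound 3 `O=C(/C=C/c1cccc(S(=O)(=O)c2ccc3cccc(Cl)c3n2)c1)NO` is not yet measured. Its difference from compound 2 is chloro in place of fluoro on an aromatic carbon and in words is chloro in place of fluoro on an aromatic carbon, ortho to a fused ring and meta to a fused ring. Only the modest step of a 2.4-fold higher number from compound 1 to compound 2 (0.37 log units; beyond the scatter) bears on this change. For the measured compounds named here, that step replaced hydrogen and not fluoro, so no measured step shows what chloro does here. A shift in this assay beyond the scatter is therefore not expected, and a slight further rise is the likelier direction. The estimated step of a 1.1-fold higher number from compound 2 to compound 3 (0.04 log units; within the scatter) is expected to stay within the scatter. For compound 3 the expected value is 700 nM with an estimated range from 320 nM to 1500 nM for the measurement to come.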

Compound 3, concentration for 50% growth inhibition: 1420 nM
For compound 3 the middle estimate is 2.0-fold (0.31 log units) below the measured one; the measured number falls inside the stated range.
By their numbers in this assay, from the lowest: compound 1; then compound 2; then compound 3.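

In this assay this carbon, ortho to a fused ring and meta to a fused ring, responds to which halogen it carries and not only to whether a halogen is present: chloro in place of fluoro gives a 2.2-fold higher number from compound 2 to compound 3 (0.35 log units; beyond the scatter) and so adds a further loss to the one fluoro had already brought. Measured against hydrogen, chloro in place of hydrogen gives a 5.3-fold higher number from compound 1 to compound 3 (0.72 log units; beyond the scatter), which makes compound 3 the weakest inhibitor of growth of the three and sets the order at this carbon as hydrogen, then fluoro, then chloro, with no compound among these three going against it. The data on hand offer no measurement that accounts for this order.

Three compounds cannot show whether the trend continues to bromo, or whether it is tied to halogens at all, and a methyl, a methoxy or an amine on the same carbon could fall anywhere relative to hydrogen. As far as these compounds go, it also remains open whether chloro or fluoro on other carbons of the shared core would give the same order, or whether hydrogen stays the best of the options at those carbons.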